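This account rests on a few compounds, and the source may have more. Where it says the series, first, only, none or still open, it means among the compounds named here.

Three compounds have numbers in a functional assay on NCI-H441 cells (Homo sapiens) for antiproliferative activity, with a stated time of 24 h; on this read-out higher numbers stand for weaker inhibition and lower numbers for stronger inhibition. Compound 1 (`O=C1/C(=C/c2ccccc2Br)CNC/C1=C\c1ccccc1Br`) gives 6000 nM, compound 2 (`OC1/C(=C/c2ccccc2F)CNC/C1=C\c1ccccc1F`) gives 124000 nM, and compound 3 (`O=C(O)CCCC(=O)N1C/C(=C\c2ccccc2F)C(=O)/C(=C/c2ccccc2F)C1`) gives 60000 nM. Compound 3 therefore holds the second highest of the three numbers. It lies nearest to compound 2 and furthest from compound 1, and both gaps are beyond the usual scatter. No two of these compounds differ in just one place, so the measured set offers no single-change step to draw on.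

Compound 4 (`Cc1ccc(S(=O)(=O)N2C/C(=C\c3ccccc3F)C(=O)/C(=C/c3ccccc3F)C2)cc1`) has not yet been measured. It shares the core of compound 3 and differs in one place, with (4-methylphenyl)sulfonyl in place of (3-carboxypropyl)carbonyl on an amine nitrogen in a ring. The expectation is only loosely grounded: compound 3 at 60000 nM sits toward the weak end of the measured numbers, while compound 1 at 6000 nM shows that much lower numbers occur in this small set. A move toward a lower number in this assay, beyond the scatter, is therefore expected, with an estimated size of a 7.5-fold lower number from compound 3 to compound 4 (0.88 log units; beyond the scatter). For compound 4 the estimated value is 8000 nM, with an expected range of 1500 nM to 40000 nM.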

Compound 4, half-maximal inhibitory concentration: 50000 nM
Compound 4: middle estimate off by 6.3-fold (0.80 log units), on the low side; measured number above the stated range.
By their numbers in this assay, from the lowest: compound 1; then compounds 4 and 3 (each within the scatter of the next); then compound 2.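

In this assay, going by these compounds alone, the replacement of (3-carboxypropyl)carbonyl by (4-methylphenyl)sulfonyl on an amine nitrogen in a ring gives the first single-change step in this set, a 1.2-fold lower number from compound 3 to compound 4 (0.08 log units; within the scatter). The two groups differ considerably in what is counted for them: the group that leaves has no ring and one hydrogen-bond donor, whereas the group that enters has a six-membered aromatic ring and no hydrogen-bond donor. Even so, this exchange at this place does not separate compound 3 and compound 4 on this read-out, which the earlier compounds, with no single-change step among them, could not show, and no measurement is available that would explain the result.

Going by these compounds, whether a smaller acetyl group, a benzoyl group or a methanesulfonyl group on the same nitrogen would also stay within the scatter of compound 3 and compound 4 remains open. Compound 1, with a free amine and bromine in place of fluorine, differs from both in more than one place, so the compounds shown do not tell whether its lower number comes from the nitrogen, the halogen or both.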